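A methoxy rearrangement in a flat series

A few compounds are considered here, and "the series" means these few. Any claim that something is new, unique, unknown or untested is made for them only; others in the source may bear on it.

In a functional assay on L1210 cells (Mus musculus) for antiproliferative activity, read by MTT assay, with a stated time of 72 h (a lower number here means a stronger inhibitor, a higher number a weaker inhibitor), compound 1 (`COc1ccc(C2OC(c3cc(OC)c(OC)c(OC)c3)=NN2C(C)=O)cc1`) gives 57000 nM, compound 2 (`COc1cccc(C2OC(c3cc(OC)c(OC)c(OC)c3)=NN2C(C)=O)c1`) gives 45000 nM and compound 3 (`COc1ccc(OC)c(C2OC(c3cc(OC)c(OC)c(OC)c3)=NN2C(C)=O)c1`) gives 55000 nM. Compound 3 thus stands within the scatter of both other compounds, and the three numbers cannot be ranked. Compound 4 (`COc1cc(OC)cc(C2OC(c3cc(OC)c(OC)c(OC)c3)=NN2C(C)=O)c1`) has 3,5-dimethoxyphenyl in place of 2,5-dimethoxyphenyl on a saturated ring carbon. Three measured steps alter the same aryl group and bear on this change: a 1.3-fold lower number from compound 1 to compound 2 (0.10 log units; within the scatter), a 1.0-fold lower number from compound 1 to compound 3 (0.02 log units; within the scatter) and a 1.2-fold higher number from compound 2 to compound 3 (0.09 log units; within the scatter). None of them leaves the scatter, so no step beyond the scatter is expected in this assay, and no direction can be called. Among the measured compounds shown here, the 3,5-dimethoxyphenyl group itself has no measured precedent here, which leaves the expectation open to some doubt. The expected change is small, with an estimated 1.1-fold lower number from compound 3 to compound 4 (0.04 log units; within the scatter). For compound 4 the estimated value is 50000 nM, with an expected range of 24000 nM to 95000 nM.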

Compound 4, half-maximal inhibitory concentration: 5900 nM
Estimate against measurement, compound 4: 8.5-fold (0.93 log units) above, outside the stated range (below it).
By their numbers in this assay, from the lowest: compound 4; then compounds 2, 3 and 1 (each within the scatter of the next).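

In this assay, the arrangement of the methoxy groups on the aryl group at the saturated ring carbon turns out to matter: 3,5-dimethoxyphenyl in place of 2,5-dimethoxyphenyl gives a 9.3-fold lower number from compound 3 to compound 4 (0.97 log units; beyond the scatter) in a series whose earlier steps all stayed within the scatter. Against the single-methoxy compounds the result is similar, with a 7.6-fold lower number from compound 2 to compound 4 (0.88 log units; beyond the scatter) on adding a methoxy group and a 9.7-fold lower number from compound 1 to compound 4 (0.99 log units; beyond the scatter) on exchanging 4-methoxyphenyl for 3,5-dimethoxyphenyl. The number of methoxy groups alone does not set the level, as compound 3 also carries two and stays within the scatter of compound 1 and compound 2. Nothing available bears on the reason for this gap.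

The compounds shown leave open whether the step depends on methoxy itself or would persist with 3,5-dimethylphenyl or 3,5-dichlorophenyl at this carbon. They also leave open whether 3,4,5-trimethoxyphenyl there would go further.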